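Phenyl for pyridin-4-yl on the ring amine nitrogen

A few compounds are considered here, and "the series" means these few. Any claim that something is new, unique, unknown or untested is made for them only; others in the source may bear on it.

Within the data shown here, compound 1 `Nc1ccccc1NC(=O)c1ccc(CSC(=S)N2CCN(c3ccncc3)CC2)cc1` gives the highest of the three numbers measured so far. In a functional assay on HeLa cells (Homo sapiens) for antiproliferative activity, read by CCK-8 assay, with a stated time of 72 h, tested at 8 uM (a higher number here means a stronger effect of the compound at the concentration tested, a lower number a weaker effect), compound 1 gives 77.4%. Compound 3 `Nc1ccccc1NC(=O)c1ccc(CSC(=S)N2CCc3ccccc32)cc1` comes nearest, giving 67% in this assay, a gap beyond the scatter. Compound 2 `Nc1ccccc1NC(=O)c1ccc(CSC(=S)N(Cc2ccccc2)Cc2ccccc2)cc1` stands furthest, with 18.9% in this assay, also beyond the scatter. The three share one core and differ only in the amine part attached to it; the two compounds in which that amine sits in a ring give the larger numbers, the open-chain pair of benzyl groups in compound 2 the smallest.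

Compound 4 `Nc1ccccc1NC(=O)c1ccc(CSC(=S)N2CCN(c3ccccc3)CC2)cc1` has not yet been measured. It differs from compound 1 in one place: phenyl in place of pyridin-4-yl on an amine nitrogen in a ring. Among the measured compounds shown here, no pair of measured compounds differs by this change alone, so the size of the step is uncertain. Because compound 1 gives 77.4% and the ring amine is kept, the step of a number 7.4 percentage points lower from compound 1 to compound 4 (within the scatter) is expected to be small, downward if anything, and within or near the scatter. Compound 4 is estimated at 70%, with a range from 52% to 85%.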

Compound 4, a percentage reported as inhibition, at one concentration (the size of the read-out at that concentration, not a potency): 73.1%
Compound 4: middle estimate off by 3.1 percentage points, on the low side; the measured number falls inside the stated range.
By their numbers in this assay, from the lowest: compound 2; then compounds 3, 4 and 1 (each within the scatter of the next, the first and the last beyond it).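

Phenyl in place of pyridin-4-yl on an amine nitrogen in a ring gives, in this assay, a number 4.3 percentage points lower from compound 1 to compound 4 (within the scatter), the first step in the series that changes one place only. Removing the ring nitrogen and the hydrogen-bond acceptor counted with pyridin-4-yl therefore leaves the read-out within the scatter, so neither is required at this position for the effect seen at the concentration tested. No measurement at hand gives a reason for this result.

Still open, as far as these compounds go, is whether the aromatic ring itself is needed on that amine nitrogen, which a methyl or an acetyl group there would test. Also open, from the compounds shown here alone, is how a fluoro or methoxy group on the phenyl would change the read-out, and how the compounds compare in potency, which a single concentration cannot show.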